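Benzoxaborole amides: distal aryl substitution in the biphenyl arm

The source may report more compounds than this note shows. Statements on the series, on what has been measured and on what is new or still open speak of the compounds shown alone.

In a functional assay on MDA-MB-231 cells (Homo sapiens) for antiproliferative activity, read by MTT assay, with a stated time of 72 h (a higher number here means a weaker inhibitor, a lower number a stronger inhibitor), the series ranges from compound 1 `Cc1ccc(NC(=O)CCc2cccc3c2B(O)OC3)cc1` at 1100 nM and compound 2 `COc1ccccc1NC(=O)CCc1cccc2c1B(O)OC2` at 930 nM down to compound 3 `O=C(CCc1cccc2c1B(O)OC2)Nc1cccc(-c2ccccc2)c1` at 220 nM, the lowest number of the three, with both gaps to it beyond the scatter. Compound 4 `O=C(CCc1cccc2c1B(O)OC2)Nc1cccc(-c2ccc(C(F)(F)F)cc2)c1` is the next case and differs from compound 3 in one place: trifluoromethyl in place of hydrogen on an aromatic carbon. No pair differing only in this way has been measured in this assay, so the size of the step is not fixed by the numbers shown. A step of a 1.2-fold lower number from compound 3 to compound 4 (0.09 log units; within the scatter) is expected, small and within the scatter of compound 3. For compound 4 a value of 180 nM is estimated, with a range from 70 nM to 500 nM.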

Compound 4, half-maximal inhibitory concentration: 510 nM
The estimate for compound 4 lay 2.8-fold (0.45 log units) below the measured number, and the stated range ends below it.
By their numbers in this assay, from the lowest: compound 3; then compounds 4, 2 and 1 (each within the scatter of the next, the first and the last beyond it).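

Going from phenyl to 4-(trifluoromethyl)phenyl gives a 2.3-fold higher number from compound 3 to compound 4 (0.37 log units; beyond the scatter) in this assay, the first one-place step in the series, so this aromatic carbon is sensitive to substitution and trifluoromethyl is not tolerated there without loss. Compound 3, with hydrogen at this carbon, therefore remains the better of this pair. No supporting data bear on the reason for this step.

Open, going by these compounds, is whether a fluorine atom, a methoxy group or a carboxylic acid at the same carbon would give a step of similar size. Also open, on these data alone, is whether trifluoromethyl elsewhere on this ring would behave alike.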